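Trimming a tert-butyl group from a triazole nucleoside

A few compounds are considered here, and "the series" means these few. Any claim that something is new, unique, unknown or untested is made for them only; others in the source may bear on it.

Compound 1 `CC(=O)OC[C@H]1O[C@@H](n2cc(-c3cc(-c4ccccc4)no3)c(=O)[nH]c2=O)C[C@@H]1OC(C)=O` and compound 2 `CC(C)(C)c1ccc(Cn2cc(-c3cn([C@H]4C[C@H](O)[C@@H](CO)O4)c(=O)[nH]c3=O)nn2)cc1` were both tested in a functional assay on HCT-15 cells (Homo sapiens) for cytotoxicity, read by sulforhodamine B assay, tested at 10 uM; on this read-out higher numbers stand for more inhibition at the one concentration tested (going by the name of the read-out) and lower numbers for less inhibition. In this assay compound 1 gives 92.2%, and compound 2 gives 96.9%. Of these two numbers, compound 2 has the nominally higher one, but its gap to compound 1 lies within the usual scatter, so neither can be called stronger. Compound 3 `O=c1[nH]c(=O)n([C@H]2C[C@H](O)[C@@H](CO)O2)cc1-c1cn(Cc2ccccc2)nn1` differs from compound 2 by hydrogen in place of tert-butyl on an aromatic carbon. Among the measured compounds shown here, with no measured pair showing what such a change does here, the step is expected to be small, a number 6.9 percentage points lower from compound 2 to compound 3 (within the scatter), not beyond the scatter. Compound 3 is therefore estimated at 90%, within a range of 70% to 99%.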

Compound 3, a percentage reported as inhibition, at one concentration (the size of the read-out at that concentration, not a potency): 88.3%
Compound 3: middle estimate off by 1.7 percentage points, on the high side, and the stated range covers the measured number.
By their numbers in this assay, from the lowest: compounds 3, 1 and 2 (each within the scatter of the next).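

Within this assay the swap of tert-butyl for hydrogen gives a number 8.6 percentage points lower from compound 2 to compound 3 (within the scatter) and so the plain phenyl compound cannot be told apart from its 4-(tert-butyl)phenyl partner. At this place on the ring, the tert-butyl group is therefore not needed for the inhibition seen at the one concentration tested. No available measurement offers an explanation for this result.

As far as these compounds go, whether a methoxy group or an amine at the same place would behave alike remains open. So does whether compound 2 and compound 3 would separate at a lower concentration.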